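Amide-side exchange on the shared core: pyrimidinyl for fluorophenyl

A few compounds are considered here, and "the series" means these few. Any claim that something is new, unique, unknown or untested is made for them only; others in the source may bear on it.

Compound 1 `CC(C)n1ncc2c(C(=O)Nc3ccc(F)cc3)cc(-c3cccs3)nc21` sits at the edge of what an ADME assay on LLC-MK2 cells (Macaca mulatta) for cytotoxicity, read by spectrophotometry and crystal violet staining, with a stated time of 4 days (on this read-out lower numbers stand for higher toxicity in this test and higher numbers for lower toxicity in this test), reports: in this assay compound 1 gives > 200000 nM, which is a limit of the assay and not a number (the limit of > 200000 nM in this assay, at which 1 of the 2 values shown sits). Compound 2 `CC(C)n1ncc2c(C(=O)Nc3ccc(F)cc3)cc(C3CC3)nc21` carries cyclopropyl in place of thiophen-2-yl on an aromatic carbon, and in this assay compound 2 gives 12500 nM. Going by the values given here, the only measured step, an at least 16-fold lower number from compound 1 to compound 2 (1.20 log units; beyond the scatter), concerns that aromatic carbon and says nothing about the amide-type nitrogen.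

Compound 3 `CC(C)n1ncc2c(C(=O)Nc3ccncn3)cc(-c3cccs3)nc21` differs from compound 1 at the amide-type nitrogen: pyrimidin-4-yl in place of 4-fluorophenyl on an amide-type nitrogen. Among the compounds with values here, no measured step touches this place, so there is no measured basis for a shift beyond the scatter in this assay. The step from compound 1 to compound 3 is therefore expected to be small, a number no higher from compound 1 to compound 3 (the limit leaves the size open). Compound 3 is estimated to give about 200000 nM in this assay, within 60000 nM to 400000 nM, and a limit rather than a number is the more likely read-out for compound 3.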

Compound 3, half-maximal cytotoxic concentration: 50000 nM
For compound 3 the middle estimate is 4.0-fold (0.60 log units) above the measured one; measured number below the stated range.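

The amide-type nitrogen is a place that moves the read-out in this assay: with thiophen-2-yl held constant, pyrimidin-4-yl in place of 4-fluorophenyl gives an at least 4.0-fold lower number from compound 1 to compound 3 (0.60 log units; beyond the scatter). The earlier step concerned only the aromatic carbon, and this result adds a second place in the series where a single exchange lies beyond the scatter, here towards higher toxicity in this test. Compound 1 gives only a limit of the assay and not a number, which leaves the full size of the step open: the limit of > 200000 nM in this assay, at which 1 of the 3 values shown sits.

The exchange removes a fluorine and a carbon-only ring and brings in a ring with 2 hetero atoms in one change, and the compounds shown do not separate these parts; an unsubstituted phenyl or a pyridin-4-yl on the amide-type nitrogen would bear on that. From the compounds shown here alone, it also remains open whether pyrimidin-4-yl on the amide-type nitrogen lowers the number to a similar degree when cyclopropyl, as in compound 2, stands on the aromatic carbon in place of thiophen-2-yl.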